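The compounds below may be only part of what the source reports. "The series", "measured", "known", "first", "only" and "open" are said of these compounds alone.

Among the measured compounds shown here, compound 2, `COC(=O)C(Nc1cc(NS(=O)(=O)/C=C/c2c(OC)cc(OC)cc2OC)ccc1OC)c1ccccc1`, gives 2500 nM in a functional assay on K562 cells (Homo sapiens) for cytotoxicity, read by trypan blue exclusion, with a stated time of 96 h (on this read-out higher numbers stand for weaker inhibition and lower numbers for stronger inhibition), the highest of the two numbers measured; compound 1, `COC(=O)C(C)Nc1cc(NS(=O)(=O)/C=C/c2c(OC)cc(OC)cc2OC)ccc1OC`, gives 300 nM in this assay, and the only known step, an 8.3-fold higher number from compound 1 to compound 2 (0.92 log units; beyond the scatter), concerns a different change. Compound 3, `COc1cc(OC)c(/C=C/S(=O)(=O)Nc2ccc(OC)c(NC(C(=O)O)c3ccc(F)cc3)c2)c(OC)c1`, differs from compound 2 by carboxy(4-fluorophenyl)methyl in place of methoxycarbonyl)(benzyl on a nitrogen on an aromatic ring. For the measured compounds named here, no measured step bears on this change, so the direction is uncertain; a step of a 1.6-fold higher number from compound 2 to compound 3 (0.20 log units; within the scatter) is expected, somewhat weaker than compound 2 but not beyond a wide range. Compound 3 is therefore estimated at 4000 nM, within 1200 nM to 15000 nM.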

Compound 3, half-maximal inhibitory concentration: 20 nM
Beside the measured number, compound 3's estimate is 200-fold (2.30 log units) above it; measured number below the stated range.
By their numbers in this assay, from the lowest: compound 3; then compound 1; then compound 2.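

Among the compounds shown here, at the nitrogen on an aromatic ring, the earlier compounds showed only a rise in the number, whereas carboxy(4-fluorophenyl)methyl moves it sharply down in this assay: there is a 130-fold lower number from compound 2 to compound 3 (2.10 log units; beyond the scatter) and a 15-fold lower number from compound 1 to compound 3 (1.18 log units; beyond the scatter). Compound 3 therefore has the lowest number of the three. Nothing at hand accounts for this drop.

From the compounds shown here alone, the carboxy group and the fluorine enter together, so their separate shares remain unknown. Going by these compounds, whether a carboxamide or a tetrazole could stand in place of the carboxy group also stays open.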